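A few compounds are considered here, and "the series" means these few. Any claim that something is new, unique, unknown or untested is made for them only; others in the source may bear on it.

Measured compounds:
- Compound 1, `C#CCNCc1cn(-c2cc(NC(=S)NCC)ncn2)cn1`, in an assay on isolated protein for inhibition of Amine oxidase [flavin-containing] B (Homo sapiens), read by fluorescence and Amplex Red, with a stated time of 15 min (on this read-out lower numbers stand for stronger inhibition and higher numbers for weaker inhibition), compound 1 gives 5240 nM.
- Compound 2, `C#CCN(CC)Cc1cn(-c2cc(NC(=S)NCC)ncn2)cn1`, gives only a limit of this assay, > 50000 nM.
- Compound 3, `C#CCN(CCC)Cc1cn(-c2cc(NC(=S)NCC)ncn2)cn1`, likewise gives only a limit, > 50000 nM.

Compound 3 therefore stands at the limit of > 50000 nM in this assay, at which 2 of the 3 values shown sit, and no number is known for it. The path from compound 1 to compound 3 shows that substitution on the amine nitrogen costs activity: the step of an at least 9.5-fold higher number from compound 1 to compound 3 (0.97 log units; beyond the scatter) and the parallel step an at least 9.5-fold higher number from compound 1 to compound 2 (0.97 log units; beyond the scatter) both run to the limit. Between compound 2 and compound 3 the step that the two limits leave unreadable from compound 2 to compound 3 cannot be read, as both sit at the limit.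

Compound 4, `C#CCN(Cc1cn(-c2cc(NC(=S)NCC)ncn2)cn1)C(C)=O`, differs from compound 3 by acetyl in place of propyl on an amine nitrogen. The substituent on that nitrogen is swapped for another of the same size, so the amine nitrogen again carries no hydrogen. The two steps that bear on it, from compound 1 to compound 2 and from compound 1 to compound 3, were each at least modest and in the direction of weaker inhibition once the hydrogen was replaced. For the measured compounds named here, nothing among the measured compounds shows that a different substituent on that nitrogen recovers activity. Compound 4 is therefore expected to remain at or near the limit, with the step that the limit leaves unreadable from compound 3 to compound 4 estimated to be small. The estimate for compound 4 in this assay is 60000 nM, within 15000 nM to 300000 nM.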

Compound 4, half-maximal inhibitory concentration: > 50000 nM
Compound 4: a limit, no number (the forecaster's own chance of this, stated with the estimate: 70%); the middle value does not contradict the limit.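

In this assay compound 4 gives only a limit, > 50000 nM. The acetyl group brings a carbonyl and a hydrogen-bond acceptor to the amine nitrogen, yet like ethyl and propyl it yields no number, so the result at this position extends beyond plain alkyl chains: replacing the hydrogen on that nitrogen again gives an at least 9.5-fold higher number from compound 1 to compound 4 (0.97 log units; beyond the scatter), and among the compounds shown only the one that keeps that hydrogen has a measured number. The steps among compound 2, compound 3 and compound 4 cannot be read, so the ethyl, propyl and acetyl groups cannot be ranked against one another, and the set now rests largely on one boundary of the read-out: the limit of > 50000 nM in this assay, at which 3 of the 4 values shown sit.

Going by these compounds, whether a methyl on that nitrogen still gives a number remains open, as does whether a larger group carrying a ring, such as benzyl, or a sulfonyl group would behave in the same way. On these data alone, how far the three compounds at the limit actually lie from one another also stays unknown, and so does whether the hydrogen itself is needed or only the absence of a larger group.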